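The compounds below may be only part of what the source reports. "The series", "measured", "known", "first", "only" and "open" are said of these compounds alone.

Compound 2, `N#CC1=C(N)Oc2c(N)cc3nc4ccccc4nc3c2C12C(=O)N(Cc1cnnn1-c1ccccc1Cl)c1ccccc12`, was tested in a functional assay on A549 cells (Homo sapiens) for antiproliferative activity, read by MTT assay, with a stated time of 48 h (a lower number here means a stronger inhibitor, a higher number a weaker inhibitor), where compound 2 gives 29800 nM. Within the data shown here, its only companion with a measurement is compound 1, `N#CC1=C(N)Oc2c(c3nc4ccccc4nc3c3ccccc23)C12C(=O)N(Cc1cnnn1-c1ccc(Br)cc1)c1ccccc12`, which in this assay gives 44300 nM. Among the measured compounds shown here, these two values are within the usual scatter of each other, so neither compound can be called stronger or weaker on this evidence, and there is no measured pair of compounds that differs in only one place from which the size of any single change could be read.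

The step from compound 2 to compound 3 is the next to follow. Compound 3 is `N#CC1=C(N)Oc2c(N)cc3nc4ccccc4nc3c2C12C(=O)N(Cc1cnnn1-c1ccc(F)c(Cl)c1)c1ccccc12`. The change is 3-chloro-4-fluorophenyl in place of 2-chlorophenyl on an aromatic nitrogen. Nothing measured shows what such a change does here, so the expectation for compound 3 is kept close to compound 2: no step beyond the scatter, in either direction, with the step from compound 2 to compound 3 estimated as a 1.0-fold higher number from compound 2 to compound 3 (0.00 log units; within the scatter). On that basis compound 3 is expected to give about 30000 nM in this assay, with a range from 12000 nM to 75000 nM.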

Compound 3, half-maximal inhibitory concentration: 43400 nM
The estimate for compound 3 lay 1.4-fold (0.16 log units) below the measured number; the range from low to high includes it.
By their numbers in this assay, from the lowest: compounds 2, 3 and 1 (each within the scatter of the next).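

In this assay, among these compounds, the exchange of 2-chlorophenyl for 3-chloro-4-fluorophenyl gives a 1.5-fold higher number from compound 2 to compound 3 (0.16 log units; within the scatter), the first step that can be read at a single place. At this position on an aromatic nitrogen, on the core shared by these two compounds, the assay therefore does not separate the two halogen-bearing phenyl groups, even though the entering group carries one more heavy atom. Nothing available accounts for this result or tells what the two groups do at this position.

From the compounds shown here alone, whether any group at this position can produce a step beyond the scatter remains open, for instance an unsubstituted phenyl, a benzyl, a pyridine ring, a longer alkyl chain, or a phenyl bearing an amine or a carboxylic acid. Going by these compounds, compound 1 differs from compound 2 and from compound 3 in more than one place, so the steps to it cannot be read, and the separate contributions of its core and its bromine-bearing phenyl group also remain open.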